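Three Measured Compounds, All Sitting at the Assay Limit

The source may hold more compounds than are shown below. What is called first, only, known or untested is meant among the compounds shown, and "the series" means these compounds.

Compound 1 `C=CCONC(=O)Cn1cc(C(=O)NCC(=O)N[C@H](C(=O)O)C(C)C)c2ccccc21` gives in a functional assay on MRC5 cells (Homo sapiens) for inhibition, read by microscopy and resazurin assay, with a stated time of 72 h (on this read-out lower numbers stand for stronger inhibition and higher numbers for weaker inhibition), a value of > 128000 nM, which is a limit of the assay.
Compound 2 `C=CCONC(=O)Cn1cc(C(=O)NCC(=O)N[C@@H](CC(C)C)C(=O)O)c2ccccc21` gives in this assay > 128000 nM, again a limit.
Compound 3 `CC(C)[C@H](NC(=O)CNC(=O)c1cn(CC(=O)NOCc2ccccc2)c2ccccc12)C(=O)O` gives in this assay > 128000 nM, also a limit.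

Compound 3 therefore stands where every measured compound stands, at the limit of > 128000 nM in this assay, at which 3 of the 3 values shown sit. Compound 4 `CC(C)C[C@H](NC(=O)CNC(=O)c1cn(CC(=O)NOCc2ccccc2)c2ccccc12)C(=O)O` differs from compound 3 by isobutyl in place of isopropyl on a saturated chain carbon bound to an amide-type nitrogen and a carbonyl carbon. The same change was already tried once, as a step that the two limits leave unreadable from compound 1 to compound 2, and the other change that separates compound 3 from compound 1 is a step that the two limits leave unreadable from compound 1 to compound 3; both steps are unreadable, each end sitting at the limit. No step beyond the scatter can be expected in this assay in either direction, and compound 4 is expected to remain at the limit. The estimate for compound 4 is 200000 nM, with a range from 100000 nM to 800000 nM. The step expected from this is a step that the limit leaves unreadable from compound 3 to compound 4.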

Compound 4, half-maximal inhibitory concentration: > 128000 nM
Compound 4 gave a limit, no number; the forecaster's own chance of this, stated with the estimate: 90%; the middle value does not contradict the limit.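

Compound 4 sits at a limit, as do compound 1, compound 2 and compound 3, so no step among them can be read in this assay: the limit of > 128000 nM in this assay, at which 4 of the 4 values shown sit.

These compounds leave open whether isobutyl in place of isopropyl, or phenyl in place of vinyl, changes the read-out at all.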